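Swapping the aryl group on the amide of compound 2

This account rests on a few compounds, and the source may have more. Where it says the series, first, only, none or still open, it means among the compounds named here.

Measured compounds:
- Compound 1 `Cn1c(Cc2nn(C)c(=O)c3ccccc23)nnc1SCCCCCCCC(=O)Nc1ccc(Cl)cc1Cl`: 1900 nM
- Compound 2 `Cn1c(Cc2nn(C)c(=O)c3ccccc23)nnc1SCCCCCCCC(=O)Nc1ccccc1O`: 27000 nM

The two measured compounds share one core and differ only in the ring on the amide-type nitrogen. In an assay on isolated protein (Mus musculus) for inhibition of IL15-IL15 receptor (Homo sapiens), read by resazurin assay, with stated times of 30 min and 2.5 days (on this read-out higher numbers stand for weaker inhibition and lower numbers for stronger inhibition), compound 1 gives 1900 nM, and compound 2 gives 27000 nM. For the measured compounds named here, compound 2 thus stands with the highest number of the two, and its only neighbour is compound 1, from which it is separated by a 14-fold higher number from compound 1 to compound 2 (1.15 log units; beyond the scatter).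

Compound 3 `Cn1c(Cc2nn(C)c(=O)c3ccccc23)nnc1SCCCCCCCC(=O)Nc1ccc(F)cc1F` has not yet been measured. It differs from compound 2 by 2,4-difluorophenyl in place of 2-hydroxyphenyl on an amide-type nitrogen. Going by the values given here, the one step that bears on this change is the one from compound 1 to compound 2, in which the 2,4-dichlorophenyl ring was swapped for 2-hydroxyphenyl and the number rose by a 14-fold higher number from compound 1 to compound 2 (1.15 log units; beyond the scatter). Compound 3 moves back toward a doubly halogenated ring, though with fluorine rather than chlorine, so a partial return toward the number of compound 1 is expected, with the size uncertain.

For compound 3 the expected step is a 6.0-fold lower number from compound 2 to compound 3 (0.78 log units; beyond the scatter), giving an estimate of 4500 nM with a range from 1300 nM to 16000 nM.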

Compound 3, half-maximal inhibitory concentration: 2300 nM
Compound 3: the middle estimate sits 2.0-fold (0.29 log units) above what was measured; low and high end bracket the measured number.
By their numbers in this assay, from the lowest: compounds 1 and 3 (each within the scatter of the next); then compound 2.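

In this assay, 2,4-difluorophenyl in place of 2-hydroxyphenyl on the amide-type nitrogen gives a 12-fold lower number from compound 2 to compound 3 (1.07 log units; beyond the scatter), a large step that shows compound 2 is the outlier of the three and that the number can be recovered at this position without chlorine. The comparison with the dichlorinated ring gives a 1.2-fold higher number from compound 1 to compound 3 (0.08 log units; within the scatter), so fluorine and chlorine cannot be told apart here when both sit on the ring in the 2,4-pattern, and this position accepts either pair of halogens equally within the scatter. Nothing available for these compounds explains why the two halogenated rings read alike or why the 2-hydroxyphenyl ring stands apart.

On these data alone, the ring of compound 2 differs from the other two in two ways at once, as it gains a hydroxyl group and lacks halogens, so it remains open which of these goes with its higher number; a plain phenyl ring or a 2-methoxyphenyl ring would help to separate them. As far as these compounds go, it also remains open whether both halogens are needed, which a 4-chlorophenyl or 4-fluorophenyl ring would test.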